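The compounds below may be only part of what the source reports. "The series", "measured", "known", "first", "only" and "open" are said of these compounds alone.

Values measured in a functional assay on HepG2 cells (Homo sapiens) for antiproliferative activity, with a stated time of 72 h; on this read-out higher numbers stand for an effect only at larger amounts of compound and lower numbers for an effect already at smaller amounts:
Compound 1 `COc1ccc(-c2cc(=O)c3c(OC)cc(OC)cc3[nH]2)cc1`: > 31100 nM
Compound 2 `COc1ccc(-c2cc(=O)c3c(OC)cc(OC)cc3n2C)cc1`: "not determined" (no result reported)
Compound 3 `COc1ccc(-c2cc(=O)c3c(OC)cc(OC)cc3n2S(=O)(=O)c2ccc(C=O)cc2)cc1`: > 34400 nM

Compound 3 has only a limit in this assay, > 34400 nM, and not a number. Compound 1 also has only a limit, > 31100 nM. For compound 2 the entry reads "not determined" (no result reported), so it gives no reference point. Among the measured compounds shown here, neither limit can be ranked against the other, and no compound in this small set has a measured number.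

Compound 4 `COc1ccc(-c2cc(=O)c3c(OC)cc(OC)cc3n2S(=O)(=O)c2cc(F)c(F)c(F)c2)cc1` keeps the sulfonyl group on the aromatic nitrogen and changes only the group on the sulfonyl sulfur, with 3,4,5-trifluorophenyl in place of 4-formylphenyl on a sulfonyl sulfur.

For the measured compounds named here, only one measured step bears on this change, a step that the two limits leave unreadable from compound 1 to compound 3. It introduced (4-formylphenyl)sulfonyl in place of hydrogen on an aromatic nitrogen, and it gives no size to carry forward. Going by the values given here, no measured step yet shows what exchanging the group on the sulfonyl sulfur does. The expectation therefore rests on compound 3, with its limit of > 34400 nM, and no step beyond the scatter is expected in this assay. The expected change is an at least 1.1-fold lower number from compound 3 to compound 4 (0.05 log units; that floor lies within the scatter). For compound 4 the estimated value is 30000 nM, with an expected range from 8000 nM to 45000 nM.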

Compound 4, half-maximal effective concentration: > 65500 nM
Compound 4 gave a limit, no number; the forecaster's own chance of this, stated with the estimate: 60%; middle value at least 2.1-fold (0.33 log units) from the limit.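

Among the compounds shown here, compound 3 and compound 4 both carry only limits in this assay, so no step between them can be read. The compounds shown leave open what exchanging 4-formylphenyl for 3,4,5-trifluorophenyl on the sulfonyl sulfur does to the read-out, and at what concentration, if any, either compound would show an effect.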